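Ester in Place of Ether on the Furan-Bearing Core

A few compounds are considered here, and "the series" means these few. Any claim that something is new, unique, unknown or untested is made for them only; others in the source may bear on it.

Measured compounds:
compound 1 `Cc1coc(-c2ccc3c(c2O)CCCC3(C)C)c1C(=O)O`: 4.7 uM
compound 2 `COCc1c(C)coc1-c1ccc2c(c1OC)CCCC2(C)C`: 20.1 uM
compound 3 `Cc1coc(-c2ccc3c(c2O)CCCC3(C)C)c1CO`: 19.9 uM

Of the compounds shown here, three sharing one core have been measured in a functional assay on KBVIN cells (Homo sapiens) for cytotoxicity, read by sulforhodamine B assay, with a stated time of 3 days; a lower number here means that less compound is needed, a higher number that more compound is needed for the effect. Compound 1 gives 4.7 uM, compound 2 gives 20.1 uM, and compound 3 gives 19.9 uM. Compound 2 therefore has the highest number of the three; its value and that of compound 3 lie within the scatter of each other, whereas compound 1 sits apart with the lowest number.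

The step now followed leads from compound 2 to compound 4 `COC(=O)c1c(C)coc1-c1ccc2c(c1OC)CCCC2(C)C`. The change is methoxycarbonyl in place of methoxymethyl on an aromatic carbon.

One measured step speaks to this change. Going from compound 1 to compound 3 gives a 4.2-fold higher number from compound 1 to compound 3 (0.63 log units; beyond the scatter), so replacing the carboxy group by hydroxymethyl raised the number on this core. The change from compound 2 to compound 4 runs the other way, from a reduced side chain to a carbonyl-bearing one, though with a methoxycarbonyl rather than a free carboxy. A modest lowering of the number is therefore expected, smaller than the step seen between compound 1 and compound 3.

In this assay compound 4 is estimated at 10 uM, with a range from 3.5 uM to 30 uM; this expected step is a 2.0-fold lower number from compound 2 to compound 4 (0.30 log units; within the scatter).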

Compound 4, concentration for half-maximal effect: 52.1 uM
For compound 4 the middle estimate is 5.2-fold (0.72 log units) below the measured one, outside the stated range (above it).
By their numbers in this assay, from the lowest: compound 1; then compounds 3 and 2 (each within the scatter of the next); then compound 4.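

In this assay, methoxycarbonyl in place of methoxymethyl on this aromatic carbon of the five-membered ring gives a 2.6-fold higher number from compound 2 to compound 4 (0.41 log units; beyond the scatter), so the position responds to a change between two capped side chains as well as to the earlier change between free ones. Set against a 4.2-fold higher number from compound 1 to compound 3 (0.63 log units; beyond the scatter), where the carbonyl-bearing carboxy member has the lower number, this step shows that a carbonyl at this position does not by itself go with a lower number: compound 4 carries one and has the higher number of its pair, which goes against the trend suggested by compound 1 and compound 3. Nothing shown here gives a measured reason for this reversal.

Compound 1 and compound 4 differ in more than one place, so the compounds shown do not separate the effect of a free carboxylic acid from that of its methyl ester on a single core. From the compounds shown here alone, how a primary amide or an aminomethyl group would behave at this position, on either the hydroxy-bearing or the methoxy-bearing form of the core, also remains open.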